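Methyl added to the outer phenyl of compound 4

A few compounds are considered here, and "the series" means these few. Any claim that something is new, unique, unknown or untested is made for them only; others in the source may bear on it.

Three sulfonamides built on a shared core have been measured in a functional assay on OVCAR-3 cells (Homo sapiens) for antiproliferative activity, read by MTT assay, with a stated time of 24 h; a lower number here means a stronger inhibitor, a higher number a weaker inhibitor. Compound 1 `O=c1[nH]cc(S(=O)(=O)Nc2ccccc2-c2cn(-c3ccccc3)nn2)c(=O)[nH]1` gives 6650 nM, compound 2 `Cc1cccc(-n2cc(-c3cccc(NS(=O)(=O)c4c[nH]c(=O)[nH]c4=O)c3)nn2)c1` gives 4080 nM, and compound 3 `O=c1[nH]cc(S(=O)(=O)Nc2ccc(-c3cn(-c4ccccc4)nn3)cc2)c(=O)[nH]1` gives 18000 nM. Among these three numbers compound 3 stands highest: the nearest, compound 1, sits well below it and beyond the scatter, and the furthest, compound 2, sits lower still. Compound 2 and compound 3 differ in two places at once, so their gap cannot be tied to either change alone.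

Compound 4 `Cc1cccc(-n2cc(-c3ccc(NS(=O)(=O)c4c[nH]c(=O)[nH]c4=O)cc3)nn2)c1` has not yet been measured. It differs from compound 3 by methyl in place of hydrogen on an aromatic carbon: a methyl in place of hydrogen on an aromatic carbon, which, seen one bond further out, reads as phenyl to 3-methylphenyl. For the measured compounds named here, no pair of measured compounds shows this single change on its own, so its effect here is not known. Compound 4 is expected to give about 12000 nM in this assay, with a range from 5000 nM to 30000 nM. This means an expected step of a 1.5-fold lower number from compound 3 to compound 4 (0.18 log units; within the scatter), a small move toward lower numbers that stays within the usual scatter.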

Compound 4, half-maximal inhibitory concentration: 7490 nM
Estimate against measurement, compound 4: 1.6-fold (0.20 log units) above, and the stated range covers the measured number.
By their numbers in this assay, from the lowest: compounds 2, 1 and 4 (each within the scatter of the next); then compound 3.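

For the compounds shown here, the pair gives the first reading of a single change in this assay: going from phenyl to 3-methylphenyl on the outer ring brings a 2.4-fold lower number from compound 3 to compound 4 (0.38 log units; beyond the scatter), a modest step but one beyond the scatter. The earlier compounds shown here could not show this, as none of them formed a pair differing in one place, and it establishes that this ring position accepts a methyl with no loss of activity, the number moving instead toward stronger inhibition. One added carbon, with no ring, no hydrogen-bond donors or acceptors and no net charge, is thus enough to produce a measurable shift on the scaffold of compound 3, though nothing shown explains the shift.

Going by these compounds, what remains open is whether the gain belongs to methyl itself or would also appear with a larger or different group at the same place, such as methoxy, chlorine, an amine or a carboxylic acid. Going by these compounds alone, also open is whether methyl would give a similar step on the outer phenyl with the sulfonamide attached elsewhere on the central ring, as that single change has no measured pair here.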